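Amide nitrogen substituent and paw edema inhibition

This account rests on a few compounds, and the source may have more. Where it says the series, first, only, none or still open, it means among the compounds named here.

Measured so far:
compound 1, `CCNC(=O)c1nc(-c2cc(OC)c(OC)c(OC)c2)n(-c2ccc(OC)cc2)n1`: 52%
compound 2, `COc1ccc(NC(=O)c2nc(-c3cc(OC)c(OC)c(OC)c3)n(-c3ccc(OC)cc3)n2)cc1`: 51%
compound 3, `COc1ccc(-n2nc(C(=O)Nc3ccccc3OC)nc2-c2cc(OC)c(OC)c(OC)c2)cc1`: 10%

Compound 3 stands lowest of the three in a functional assay on the whole organism for inhibition, with Rattus norvegicus as the target, read by paw edema, with stated times of 30 min and 5 h, at a dose of 0.28 mmol/kg by the oral route; a lower number here means less inhibition, a higher number more inhibition at the dose given (going by the name of the read-out); the next number, that of compound 2, lies beyond the scatter above it, and compound 1 lies beyond the scatter above it as well. The steps of a number 42 percentage points lower from compound 1 to compound 3 (beyond the scatter) and a number 41 percentage points lower from compound 2 to compound 3 (beyond the scatter) are both large, while a number 1 percentage points lower from compound 1 to compound 2 (within the scatter) is within the scatter.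

Compound 4, `COc1ccc(-n2nc(C(=O)Nc3ccc(C)cc3)nc2-c2cc(OC)c(OC)c(OC)c2)cc1`, is not yet measured. The change from compound 3 is 4-methylphenyl in place of 2-methoxyphenyl on an amide-type nitrogen.

Among the compounds with values here, no measured step carries a 4-methylphenyl group, so the expectation rests on the shape of the existing steps. The step of a number 41 percentage points lower from compound 2 to compound 3 (beyond the scatter) shows that the move from a 4-methoxyphenyl to a 2-methoxyphenyl group on the amide nitrogen went with a large fall. Within the data shown here, compound 4 again carries a group on that nitrogen whose substituent is named at the 4-position, as in compound 2, and a return toward the numbers of compound 1 and compound 2 is therefore expected, though the single step that supports this leaves the size uncertain. The step of a number 30 percentage points higher from compound 3 to compound 4 (beyond the scatter) is expected to be upward. Compound 4 is estimated at 40%, within a range of 15% to 60%.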

Compound 4, a percentage reported as inhibition, in the whole organism at one dose (the size of the read-out at that dose, not a potency): 42%
Beside the measured number, compound 4's estimate is 2 percentage points below it, within the range that was stated.
By their numbers in this assay, from the lowest: compound 3; then compounds 4, 2 and 1 (each within the scatter of the next).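

In this assay the low number of compound 3 does not extend to every aryl group on the amide-type nitrogen: 4-methylphenyl in place of 2-methoxyphenyl gives a number 32 percentage points higher from compound 3 to compound 4 (beyond the scatter) and so, among the aryl groups shown, the fall stays confined to 2-methoxyphenyl. Methyl in place of methoxy on an aromatic carbon gives a number 9 percentage points lower from compound 2 to compound 4 (within the scatter) and shows that, in this pair, the oxygen of the methoxy group is not needed to keep the read-out in that range, while 4-methylphenyl in place of ethyl gives a number 10 percentage points lower from compound 1 to compound 4 (within the scatter) and adds a second aryl group that cannot be told apart from the ethyl amide. Nothing measured here bears on why 2-methoxyphenyl stands apart from the other groups on this nitrogen.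

The compounds shown leave open whether 2-methylphenyl on the same nitrogen would read like 2-methoxyphenyl or like 4-methylphenyl, a comparison that would separate the methoxy group from its point of attachment. They also leave open how 4-aminophenyl, 4-carboxyphenyl or a longer chain such as butyl in place of ethyl would read in this assay at this position.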